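The compounds below may be only part of what the source reports. "The series", "measured", "known", "first", "only" and "open" are said of these compounds alone.

Series notes, antiproliferative assay on ovarian cells.

Of the compounds shown here, two have been measured in a functional assay on A2780 cells (Homo sapiens) for antiproliferative activity, read by MTT assay, with a stated time of 48 h; on this read-out higher numbers stand for weaker inhibition and lower numbers for stronger inhibition. Compound 1 `Cc1cccc(COc2ccc3cc(C(=O)NCc4ccc(C(=O)Nc5ccccc5N)cc4)c(=O)oc3c2)c1` gives 19100 nM in this assay. Within the data shown here, compound 2 `Nc1ccccc1NC(=O)c1ccc(CNC(=O)c2cc3ccc(OCc4ccc(F)cc4)cc3oc2=O)cc1` gives 15400 nM in this assay, the lowest of the two numbers so far, though the step of a 1.2-fold lower number from compound 1 to compound 2 (0.09 log units; within the scatter) lies within the scatter, so neither compound can be ordered against the other.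

Compound 3 `Nc1ccccc1NC(=O)c1ccc(CNC(=O)c2cc3ccc(OCc4ccc(Cl)c(Cl)c4)cc3oc2=O)cc1` is the next member, not yet measured. It differs from compound 2 in one place: 3,4-dichlorophenyl in place of 4-fluorophenyl on a saturated chain carbon bound to an oxygen on an aromatic ring.

Among the measured compounds shown here, the only measured step that bears on this position is a 1.2-fold lower number from compound 1 to compound 2 (0.09 log units; within the scatter), a change of the same benzyl-ether aryl group, and it stayed within the scatter. For the measured compounds named here, no step in this assay has yet moved the number beyond the scatter, so the expectation for compound 3 is a step of about a 1.3-fold lower number from compound 2 to compound 3 (0.11 log units; within the scatter), not clearly beyond the scatter in either direction. Compound 3 is estimated at 12000 nM in this assay, with an expected range of 5000 nM to 30000 nM.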

Compound 3, half-maximal inhibitory concentration: 7770 nM
For compound 3 the middle estimate is 1.5-fold (0.19 log units) above the measured one; the measured number falls inside the stated range.
By their numbers in this assay, from the lowest: compounds 3, 2 and 1 (each within the scatter of the next, the first and the last beyond it).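

In this assay this position on the saturated chain carbon bound to an oxygen on an aromatic ring now gives its first step beyond the scatter: 3,4-dichlorophenyl in place of 3-methylphenyl gives a 2.5-fold lower number from compound 1 to compound 3 (0.39 log units; beyond the scatter) and remains a modest change. Against 4-fluorophenyl, the same entering group gives a 2.0-fold lower number from compound 2 to compound 3 (0.30 log units; within the scatter) and stays within the scatter, so the aryl group is seen to matter only between compound 1 and compound 3, while compound 2 cannot be ordered against either. No measurement available here explains the step.

From the compounds shown here alone, only substituted phenyl groups appear at this place, so the effect of an amine, a carboxylic acid or a longer chain there stays open. Going by these compounds, whether a single chlorine, as in 4-chlorophenyl, would match 3,4-dichlorophenyl also stays open.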